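The compounds below may be only part of what the source reports. "The series", "measured", "known", "first", "only" and "open" are said of these compounds alone.

Values measured in an ADME assay on BE(2)-C cells (Homo sapiens) for cytotoxicity, read by MTT assay, with a stated time of 20 h; a higher number here means that more compound is tolerated, a lower number that less compound is tolerated:
- compound 1 `CC(NC(=O)C1CCN(C(=O)c2cc3ccccc3n2Cc2ccc(Cl)cc2)CC1)c1ccncc1`: 90100 nM
- compound 2 `O=C(c1cc2ccccc2n1Cc1ccc(Cl)cc1)N1CCC(C(=O)N2CCOCC2)CC1`: > 100000 nM (a limit)
- compound 3 `CN(Cc1ccccc1)C(=O)C1CCN(C(=O)c2cc3ccccc3n2Cc2ccc([N+](=O)[O-])cc2)CC1`: > 100000 nM (a limit)

Compound 3 has no exact number and stands at the limit of > 100000 nM in this assay, at which 2 of the 3 values shown sit. Compound 4 `CC(C)Cn1c(C(=O)N2CCC(C(=O)N(C)Cc3ccccc3)CC2)cc2ccccc21` carries isopropyl in place of 4-nitrophenyl on a saturated chain carbon bound to an aromatic nitrogen. Cut one bond further out, the same change reads 4-nitrobenzyl to isobutyl.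

Among the compounds with values here, no measured step touches this position. The only one, an at least 1.1-fold higher number from compound 1 to compound 2 (0.04 log units; that floor lies within the scatter), concerns a different place, the group on a carbonyl carbon, so it offers only weak guidance. Within the data shown here, compound 1 gives 90100 nM, the only exact number here, so compound 4 is expected to fall in the same high region of this assay. Compound 4 may again yield only a limit. The expected change is a number no higher from compound 3 to compound 4 (the limit leaves the size open), with no shift beyond the scatter anticipated. In this assay the estimated value for compound 4 is 100000 nM, with an expected range of 40000 nM to 200000 nM.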

Compound 4, half-maximal cytotoxic concentration: 58200 nM
Beside the measured number, compound 4's estimate is 1.7-fold (0.24 log units) above it; low and high end bracket the measured number.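

In this assay, compound 3 is recorded only as a limit (> 100000 nM). Within the data shown here, replacing 4-nitrobenzyl with isobutyl gives the only step at this position, an at least 1.7-fold lower number from compound 3 to compound 4 (0.23 log units; that floor lies within the scatter) and it shows that a group with no ring here still leaves the reading in the high region of this assay. This step gives a floor for the change rather than its true size, and the true size stays hidden behind a limit that is common among these compounds: the limit of > 100000 nM in this assay, at which 2 of the 4 values shown sit.

The compounds shown leave open whether the step follows the loss of the nitro group or the loss of the whole ring. A plain benzyl group would keep the ring without the nitro group, and a longer chain such as hexyl would test chain length at this position.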